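The source may hold more compounds than are shown below. What is called first, only, known or untested is meant among the compounds shown, and "the series" means these compounds.

Working notes on the series built on the core of compound 1 `NC(=O)[C@H]1OC(n2cnc3c(N)ncnc32)[C@H](O)[C@@H]1O`. In an assay on cell membranes for binding affinity to 2-oxoglutarate receptor 1 (Rattus norvegicus), read by radioligand binding (on this read-out higher numbers stand for weaker inhibition and lower numbers for stronger inhibition), compound 1 gives 64 nM, compound 2 `CCCCCNC(=O)[C@H]1O[C@@H](n2cnc3c(N)ncnc32)[C@H](O)[C@@H]1O` gives 12 nM, and compound 3 `CCCCCCNC(=O)[C@H]1OC(n2cnc3c(N)ncnc32)[C@H](O)[C@@H]1O` gives 19 nM. Compound 3 thus stands second highest of the three numbers: compound 2 sits within the scatter of it, while compound 1 lies beyond it. Going by the values given here, the only measured step that touches the chain, a 3.4-fold lower number from compound 1 to compound 3 (0.53 log units; beyond the scatter), is modest. Compound 4 `CCCCCCCCNC(=O)[C@H]1OC(n2cnc3c(N)ncnc32)[C@H](O)[C@@H]1O` differs from compound 3 by ethyl in place of hydrogen on a saturated chain carbon, six bonds along the chain from an amide-type nitrogen. The values of compound 2 and compound 3 show that one added chain carbon gives nothing beyond the scatter, so for compound 4 no step beyond the scatter is expected in this assay. Compound 4 is therefore estimated at 20 nM, with a range of 8 nM to 50 nM. The expected step is a 1.1-fold higher number from compound 3 to compound 4 (0.02 log units; within the scatter).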

Compound 4, inhibition constant: 21 nM
Beside the measured number, compound 4's estimate is 1.1-fold (0.02 log units) below it, and the stated range covers the measured number.
By their numbers in this assay, from the lowest: compounds 2, 3 and 4 (each within the scatter of the next); then compound 1.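

In this assay, ethyl in place of hydrogen on a saturated chain carbon, six bonds along the chain from an amide-type nitrogen, gives a 1.1-fold higher number from compound 3 to compound 4 (0.04 log units; within the scatter) and so shows that this position accepts the larger chain without a step beyond the scatter. Octyl in place of hydrogen on the amide-type nitrogen still gives a 3.0-fold lower number from compound 1 to compound 4 (0.48 log units; beyond the scatter) and stays modest, like the hexyl step. Nothing available here explains this flat stretch of the chain.

As far as these compounds go, whether a longer chain such as dodecyl keeps this level remains open. So does the effect of an amine or a carboxylic acid at the chain end.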